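Small Ester at the Shared Core: From Formate to Acetate

A few compounds are considered here, and "the series" means these few. Any claim that something is new, unique, unknown or untested is made for them only; others in the source may bear on it.

Three esters built on one core have been measured in a functional assay on HepG2 cells (Homo sapiens) for inhibition, read by MTT assay, with a stated time of 72 h; a higher number here means a weaker inhibitor, a lower number a stronger inhibitor. Compound 3 `O=COC1(C(=O)Nc2ccc([N+](=O)[O-])cc2)CCCCC1` gives 34.1 nM, the lowest of the three numbers. Compound 1 `O=C(/C=C/c1ccccc1)OC1(C(=O)Nc2ccc([N+](=O)[O-])cc2)CCCCC1` gives 52.9 nM; the change a 1.6-fold lower number from compound 1 to compound 3 (0.19 log units; within the scatter) is small. Compound 2 `O=C(OC1(C(=O)Nc2ccc([N+](=O)[O-])cc2)CCCCC1)c1ccccc1` gives 734 nM, and the change a 22-fold lower number from compound 2 to compound 3 (1.33 log units; beyond the scatter) is large. Compound 4 `CC(=O)OC1(C(=O)Nc2ccc([N+](=O)[O-])cc2)CCCCC1` differs from compound 3 by methyl in place of hydrogen on a carbonyl carbon. Among the compounds with values here, the only steps that bear on this swap the same hydrogen for much bigger groups: the ring group cost a lot, the chain group almost nothing, and a single carbon is far smaller than either. Compound 4 is therefore expected to stay close to compound 3, with a 1.3-fold higher number from compound 3 to compound 4 (0.12 log units; within the scatter), estimated at 45 nM within 18 nM to 130 nM.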

Compound 4, half-maximal inhibitory concentration: 519 nM
Estimate against measurement, compound 4: 12-fold (1.06 log units) below; the whole stated range lies below it.
By their numbers in this assay, from the lowest: compounds 3 and 1 (each within the scatter of the next); then compounds 4 and 2 (each within the scatter of the next).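

In this assay even the smallest addition on this carbonyl carbon matters: methyl in place of hydrogen gives a 15-fold higher number from compound 3 to compound 4 (1.18 log units; beyond the scatter) and so a large step. Group size does not order these esters, since a 9.8-fold higher number from compound 1 to compound 4 (0.99 log units; beyond the scatter) separates methyl from the larger 2-phenylethenyl, while a 1.4-fold lower number from compound 2 to compound 4 (0.15 log units; within the scatter) leaves methyl and phenyl within the scatter. No measurement here explains this. Open, going by these compounds, is where an ethyl group or a longer chain would fall at this position, and whether an amine attached to this carbonyl carbon would read nearer compound 3 or compound 4.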